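One Chloro Group Less: Expected Growth Inhibition of Compound 4

A few compounds are considered here, and "the series" means these few. Any claim that something is new, unique, unknown or untested is made for them only; others in the source may bear on it.

Compound 1 `ClCc1cccc(Cn2cnc3ncnc(Cl)c32)c1` gives 1940 nM in a functional assay on UACC-257 cells (Homo sapiens) for cytotoxicity, read by sulforhodamine B assay, with a stated time of 48 h; on this read-out higher numbers stand for weaker inhibition of growth and lower numbers for stronger inhibition of growth.
Compound 2 `ClCc1ccc(Cn2cnc3nc(Cl)nc(Cl)c32)cc1` gives 2230 nM in this assay.
Compound 3 `ClCc1cccc(Cn2cnc3nc(Cl)nc(Cl)c32)c1` gives 3460 nM in this assay.

All three numbers lie close together, and none of the gaps between them reaches beyond the usual scatter of this kind of measurement. Compound 3 and compound 1 differ in one place, (hydrogen in place of chloro on an aromatic carbon), and this gave a 1.8-fold lower number from compound 3 to compound 1 (0.25 log units; within the scatter). Compound 2 and compound 3 are built from the same atoms joined differently; the difference between the two cores is not broken down here.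

Compound 4 `ClCc1ccc(Cn2cnc3ncnc(Cl)c32)cc1` has not yet been measured. It differs from compound 2 by hydrogen in place of chloro on an aromatic carbon, the same change as from compound 3 to compound 1, at a place described in the same words. For the measured compounds named here, for compound 4 a step of a 1.7-fold lower number from compound 2 to compound 4 (0.23 log units; within the scatter) is expected, because the single earlier example gave a 1.8-fold lower number from compound 3 to compound 1 (0.25 log units; within the scatter). Compound 4 is therefore estimated at 1300 nM, with a plausible range from 600 nM to 2800 nM, and one example is a thin basis.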

Compound 4, concentration for 50% growth inhibition: 1580 nM
Compound 4: middle estimate off by 1.2-fold (0.08 log units), on the low side; the range from low to high includes it.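

On the core of compound 2, hydrogen in place of chloro on an aromatic carbon gives a 1.4-fold lower number from compound 2 to compound 4 (0.15 log units; within the scatter) in this assay. Set beside the earlier example of this change on the other core, the two steps agree: the same change on two cores in this assay, a 1.8-fold lower number (0.25 log units; within the scatter) from compound 3 to compound 1 and a 1.4-fold lower number (0.15 log units; within the scatter) from compound 2 to compound 4, 1.3-fold (0.10 log units) apart, within the scatter of two such steps

So among these four compounds the change carries from one core to the other with no detectable difference in size, but each step is itself within the scatter, which means that neither step shows the chloro group to matter for growth inhibition, and two cores say nothing about how the change would behave on a third.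

The compounds shown leave open whether a group other than hydrogen or chloro on this aromatic carbon, such as an amine or a methoxy group, would shift the number beyond the scatter. Also open, from the compounds shown here alone, is whether the same small steps would appear on cells of another type.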